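Amine-linked oxetane replacing the amide in the side chain

The source may report more compounds than this note shows. Statements on the series, on what has been measured and on what is new or still open speak of the compounds shown alone.

Measured compounds:
compound 1, `COc1cccc2c1c(NS(=O)(=O)c1ccc(Cl)s1)nn2Cc1cccc(CNC(=O)C2CCCO2)c1`, 39.8 nM
compound 2, `CN[C@H](C)C(=O)NCc1cccc(Cn2nc(NS(=O)(=O)c3ccc(Cl)s3)c3c(OC)cccc32)c1`, 15.9 nM
compound 3, `COc1cccc2c1c(NS(=O)(=O)c1ccc(Cl)s1)nn2Cc1cccc(CNC(=O)[C@@H]2CCCCN2)c1`, 15.9 nM

In a functional assay on CHO cells for antagonist activity at C-C chemokine receptor type 4 (Homo sapiens), read by GTPgammaS binding (on this read-out higher numbers stand for weaker inhibition and lower numbers for stronger inhibition), compound 3 gives 15.9 nM. On the numbers shown compound 3 is level with compound 2, the two together giving the lowest numbers of the three, while compound 1 gives the highest number: a 2.5-fold lower number from compound 1 to compound 3 (0.40 log units; beyond the scatter) and a 2.5-fold lower number from compound 1 to compound 2 (0.40 log units; beyond the scatter), whereas no change at the digits printed from compound 2 to compound 3 (within the scatter).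

Compound 4, `COc1cccc2c1c(NS(=O)(=O)c1ccc(Cl)s1)nn2Cc1cccc(CNC2COC2)c1`, is not yet measured. It differs from compound 3 by oxetan-3-yl in place of (piperidin-2-yl)carbonyl on an amine nitrogen. Going by the values given here, none of the measured steps bears directly on this change: each of them varies only the group on the carbonyl carbon, while here the carbonyl itself leaves and a ring sits directly on the amine nitrogen. The three measured steps show that changes at this end of the molecule move the number modestly at most. For compound 4 in this assay a somewhat higher number than for compound 3 is therefore expected, with wide uncertainty: a 2.5-fold higher number from compound 3 to compound 4 (0.40 log units; beyond the scatter). The estimate for compound 4 is 40 nM, with an expected range from 10 nM to 160 nM.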

Compound 4, half-maximal inhibitory concentration in the C-C chemokine receptor type 4 assay: 251 nM
Compound 4: the middle estimate sits 6.3-fold (0.80 log units) below what was measured; measured number outside the range, above it.
By their numbers in the C-C chemokine receptor type 4 assay, from the lowest: compounds 2 and 3 (each within the scatter of the next); then compound 1; then compound 4.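

Replacing the acyl group on the amine nitrogen with oxetan-3-yl moves the number in the C-C chemokine receptor type 4 assay much further than any earlier change of the group on the carbonyl carbon: a 16-fold higher number from compound 3 to compound 4 (1.20 log units; beyond the scatter), a 16-fold higher number from compound 2 to compound 4 (1.20 log units; beyond the scatter) and a 6.3-fold higher number from compound 1 to compound 4 (0.80 log units; beyond the scatter). All three steps point the same way, so this end of the molecule accepts different groups on the carbonyl carbon far better than it accepts this replacement of the whole acyl group. In a physicochemical assay for solubility, read by chemiluminescence, measured as kinetic solubility (on this read-out lower numbers stand for lower solubility and higher numbers for higher solubility), compound 3 gives >= 220 ug/mL, which is a limit of the assay. In the physicochemical assay compound 4 gives 122 ug/mL. In the physicochemical assay the same change reads as an at least 1.8-fold lower number from compound 3 to compound 4 (0.25 log units; that floor lies within the scatter), which is only a floor, since one of the two values is a limit of the assay: the limit of >= 220 ug/mL in the physicochemical assay, at which 1 of the 2 values shown sits.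

The compounds shown do not separate the loss of the carbonyl from the change of ring. From the compounds shown here alone, that stays open until an oxetan-3-yl carbonyl on this nitrogen, or a piperidine ring set directly on it, can be read against compound 3 and compound 4.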